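The source may report more compounds than this note shows. Statements on the series, on what has been measured and on what is new or still open speak of the compounds shown alone.

In a physicochemical assay for solubility, with a stated time of 24 h, at pH 4.5 (a higher number here means a more soluble compound, a lower number a less soluble compound), the measured compounds are:
Compound 1 `CN(C)C(=O)c1c[nH]c2ccccc12`: limit (> 47 ug/mL)
Compound 2 `COC(=O)c1ccc2c(C(=O)Nc3ccccc3)cn(C)c2c1`: limit (< 1 ug/mL)
Compound 3 `CN(C)C(=O)c1cn(C)c2ccccc12`: limit (> 51 ug/mL)

Compound 3 has no exact number and stands only at a limit (> 51 ug/mL). Compound 4 `COC(=O)c1ccc2c(C(=O)N(C)C)cn(C)c2c1` differs from it by one change: methoxycarbonyl in place of hydrogen on an aromatic carbon. Within the data shown here, the only measured step (a step that the two limits leave unreadable from compound 1 to compound 3) concerns a different change and gives no size to carry over. Compound 2 also carries methoxycarbonyl, and its value is a limit (< 1 ug/mL). Among the measured compounds shown here, with that as the only guide, a moderate fall is expected in this assay, though with wide uncertainty. The expected step is an at least 1.4-fold lower number from compound 3 to compound 4 (0.16 log units; that floor lies within the scatter). Compound 4 is estimated at 35 ug/mL, with an expected range from 8 ug/mL to 70 ug/mL.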

Compound 4, solubility: > 52 ug/mL
Compound 4 was reported as a limit (the forecaster's own chance of this, stated with the estimate: 40%); middle value at least 1.4-fold (0.17 log units) from the limit.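

In this assay, compound 4 gives > 52 ug/mL, which is a limit. The step from compound 3 cannot be read, since both values are limits, so methoxycarbonyl on this aromatic carbon has no measurable size here. Methoxycarbonyl also stands on both sides of the other new step, where dimethylamino in place of anilino on a carbonyl carbon gives an at least 52-fold higher number from compound 2 to compound 4 (1.71 log units; beyond the scatter), so this group alone does not go with a low reading.

From the compounds shown here alone, the true size of the methoxycarbonyl change stays open. So does the outcome with a carboxylic acid or an amine on that aromatic carbon.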